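Adding a Bromo Group to the Strongest of Three

A few compounds are considered here, and "the series" means these few. Any claim that something is new, unique, unknown or untested is made for them only; others in the source may bear on it.

Three compounds share most of their structure and differ in one part. In a functional assay on NZOV9 cells (Homo sapiens) for antiproliferative activity (a higher number here means a weaker inhibitor, a lower number a stronger inhibitor), compound 1 `Cc1ccc([N+](=O)[O-])cc1S(=O)(=O)N(C)/N=C/c1ncc2ccccn12` gives 1200 nM and compound 2 `Cc1ccc([N+](=O)[O-])cc1S(=O)(=O)N(C)/N=C/c1onc2ccccc12` gives 3300 nM. Compound 3 `Cc1ccc([N+](=O)[O-])cc1S(=O)(=O)N(C)/N=C/c1cncc2ccccc12` gives 500 nM, the lowest number of the three and so the strongest result. Compound 4 `Cc1ccc([N+](=O)[O-])cc1S(=O)(=O)N(C)/N=C/c1cncc2c(Br)cccc12` keeps the structure of compound 3 but has bromo in place of hydrogen on an aromatic carbon. For the measured compounds named here, no measured pair shows this change on its own, so the forecast is uncertain. In this assay, a small move towards stronger inhibition is expected, possibly none beyond the scatter, and the estimated step is a 1.4-fold lower number from compound 3 to compound 4 (0.15 log units; within the scatter). For compound 4, the estimated value is 350 nM, with an expected range of 100 nM to 1200 nM.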

Compound 4, half-maximal inhibitory concentration: 12000 nM
Beside the measured number, compound 4's estimate is 34-fold (1.54 log units) below it; measured number above the stated range.
By their numbers in this assay, from the lowest: compound 3; then compound 1; then compound 2; then compound 4.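

In this assay, putting bromo on this aromatic carbon of the carbon-only ring brings a large loss of activity: a 24-fold higher number from compound 3 to compound 4 (1.38 log units; beyond the scatter). The earlier compounds shown here showed no change at this place, and this single added heavy atom shows that the position is far from indifferent to substitution. Nothing available here explains the loss.

On these data alone, whether fluoro, methyl or an amine on this carbon would fare better remains open. So does whether bromo on another carbon of this ring would cost as much.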